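Replacing 3-Hydroxyphenyl with 4-Methylphenyl in Compound 4

The compounds below may be only part of what the source reports. "The series", "measured", "known", "first", "only" and "open" are said of these compounds alone.

Measured compounds:
compound 1, `O=C1O/C(=C\Cn2cc(-c3cc(F)cc(F)c3)nn2)C(OCc2ccccc2)=C1OCc1ccccc1`: 17700 nM
compound 2, `O=C1O[C@H]([C@@H](O)Cn2cc(-c3cccc(O)c3)nn2)C(OCc2ccccc2)=C1OCc1ccccc1`: 39300 nM
compound 3, `O=C1O/C(=C\Cn2cc(-c3ccc(Br)cc3)nn2)C(OCc2ccccc2)=C1OCc1ccccc1`: 24300 nM

All three were tested in a functional assay on HeLa cells (Homo sapiens) for antiproliferative activity, read by MTT assay, with a stated time of 72 h; a lower number here means a stronger inhibitor, a higher number a weaker inhibitor. Compound 2 gives the highest of the three numbers with 39300 nM. Compound 3, with 24300 nM, sits within the usual scatter of compound 2, so the two cannot be told apart. Compound 1, with 17700 nM, lies beyond the scatter from compound 2, so compound 1 is the stronger inhibitor of that pair.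

The unmeasured compound 4, `Cc1ccc(-c2cn(C[C@H](O)[C@H]3OC(=O)C(OCc4ccccc4)=C3OCc3ccccc3)nn2)cc1`, shares the core of compound 2 and differs from it only on the aromatic ring attached to the triazole: 4-methylphenyl in place of 3-hydroxyphenyl on an aromatic carbon.

Among the measured compounds shown here, only one measured step concerns a swap of the aryl group on the triazole, that from compound 1 to compound 3, a 1.4-fold higher number from compound 1 to compound 3 (0.14 log units; within the scatter), and it stayed within the scatter. Those two compounds carry a different core, so the guidance is indirect, but it suggests that the aryl group moves the number little. The step from compound 2 to compound 4 is therefore expected to be small, a 1.2-fold lower number from compound 2 to compound 4 (0.09 log units; within the scatter), without a clear direction.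

On that basis compound 4 is estimated at 32000 nM, with a range from 13000 nM to 80000 nM.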

Compound 4, half-maximal inhibitory concentration: 25500 nM
The estimate for compound 4 lay 1.3-fold (0.10 log units) above the measured number; measured number inside the range.
By their numbers in this assay, from the lowest: compounds 1, 3, 4 and 2 (each within the scatter of the next, the first and the last beyond it).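

In this assay, among the compounds shown here, the swap of 3-hydroxyphenyl for 4-methylphenyl on the aromatic carbon of the five-membered ring with 3 nitrogen gives a 1.5-fold lower number from compound 2 to compound 4 (0.19 log units; within the scatter), the first aryl change that can be read on the core of compound 2. The group that leaves carries 1 hydrogen-bond donor and 1 hydrogen-bond acceptor and the group that enters carries neither, yet the two compounds cannot be told apart, which matches the aryl swap on the other core, a 1.4-fold higher number from compound 1 to compound 3 (0.14 log units; within the scatter). Nothing available here offers an explanation for this result.

The names 3-hydroxyphenyl and 4-methylphenyl differ in both the group on the ring and its numbered place, so 4-hydroxyphenyl or 3-methylphenyl would be needed to separate those two changes on the core of compound 2. Also open, as far as these compounds go, is whether this position reads differently with an aryl ring bearing an amine or a carboxylic acid, or with a longer chain in place of the aryl ring.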